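This account rests on a few compounds, and the source may have more. Where it says the series, first, only, none or still open, it means among the compounds named here.

Of the compounds shown here, three have so far been measured in a functional assay on SiHa cells (Homo sapiens) for cytotoxicity, read by MTT assay, with a stated time of 48 h; a lower number here means a stronger inhibitor, a higher number a weaker inhibitor. Compound 1 `CCCCCCCCCCCCCCNC(=O)[C@@H](N)[C@@H](C)O` gives 11000 nM. Compound 2 `CCCCCCCCCCCCCCCCCCNC(=O)[C@@H](N)[C@@H](C)O` gives 39500 nM, and compound 3 `CCCCCCCCCCCCNC(=O)[C@@H](NS(=O)(=O)c1cccs1)[C@@H](C)O` gives 30900 nM. Among these three numbers, compound 2 has the highest; compound 3 lies within the scatter of it, while compound 1 sits clearly lower. For the measured compounds named here, the only single-point step among the measured compounds is a 3.6-fold higher number from compound 1 to compound 2 (0.56 log units; beyond the scatter), which shows that lengthening the chain alone raised the number.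

Compound 4 `CCCCCCCCCCCCCCCCCCNC(=O)[C@@H](NC(=O)c1ccccc1)[C@@H](C)O` differs from compound 2 in one place: benzoyl in place of hydrogen on an amine nitrogen. Going by the values given here, no measured step changes this nitrogen alone. Compound 3 carries a different group on the same nitrogen and also a shorter chain, so its value can only be set beside that of compound 2, and the two numbers lie within the scatter of each other. With nothing more to go on, the step in this assay is expected to be a 1.3-fold lower number from compound 2 to compound 4 (0.12 log units; within the scatter), that is, nothing beyond the scatter, though the range must stay wide. Compound 4 is therefore estimated at 30000 nM, with a range from 10000 nM to 90000 nM.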

Compound 4, half-maximal inhibitory concentration: 38200 nM
Beside the measured number, compound 4's estimate is 1.3-fold (0.10 log units) below it, within the range that was stated.
By their numbers in this assay, from the lowest: compound 1; then compounds 3, 4 and 2 (each within the scatter of the next).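

Compound 2 carries a free amine on this nitrogen and compound 4 a benzamido group, and in this assay this exchange of amino to benzamido reads as a 1.0-fold lower number from compound 2 to compound 4 (0.01 log units; within the scatter). For the compounds shown here, this is the first comparison that changes this nitrogen alone while the chain stays the same, and it shows that adding benzoyl, with 8 heavy atoms and a six-membered aromatic ring, leaves no difference that can be told from the scatter. No measurement on hand speaks to what lies behind this result.

From the compounds shown here alone, the reading holds only for the long chain that compound 2 and compound 4 share, so it remains open whether benzoyl would also leave the number within the scatter on the shorter chain of compound 1, which has the clearly lower number of the two amines. Going by these compounds, it also remains open whether a different group on this nitrogen, such as acetyl or a benzoyl ring bearing a carboxylic acid or an amine, would move the number beyond the scatter in this assay.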